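Boc to oxazolylmethyl on the imidazolidinone of compound 1

The compounds below may be only part of what the source reports. "The series", "measured", "known", "first", "only" and "open" are said of these compounds alone.

Measured compounds:
- compound 1, `CC(C)(C)OC(=O)N1CCN(c2cccc3c2cnn3-c2ccccc2F)C1=O`: 98.3 mL/min/kg
- compound 2, `O=C1NCCN1CCOc1nn(-c2ccccc2F)c2ccc(F)cc12`: 183 mL/min/kg
- compound 3, `O=C1NCCN1CCOc1nn(-c2ccc(F)cc2F)c2ccc(F)cc12`: 150 mL/min/kg

In an ADME assay on liver for metabolic stability, with Liver microsome (Homo sapiens) as the target, using microsomes and NADPH, with a stated time of 30 min, tested at 0.5 uM (a higher number here means faster removal of the compound, a lower number slower removal), compound 1 gives the lowest of the three numbers; compound 3 lies nearest to it and compound 2 furthest, and both gaps fall within the scatter, so no order among the three can be read. For the measured compounds named here, the one measured step, a 1.2-fold lower number from compound 2 to compound 3 (0.09 log units; within the scatter), also sits within the scatter.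

Compound 4, `O=C1N(Cc2ncco2)CCN1c1cccc2c1cnn2-c1ccccc1F`, has not yet been run in this assay. It differs from compound 1 in one place: (1,3-oxazol-2-yl)methyl in place of tert-butoxycarbonyl on an amide-type nitrogen in a ring. Neither measured step touches this change; the step from compound 2 to compound 3 concerns a fluoro on an aromatic carbon in a different core and says nothing about the group on the amide-type nitrogen in the ring. There is therefore no measured basis for a direction, and the estimate for compound 4 rests on compound 1 alone, with a wide band.

Compound 4 is expected to give about 110 mL/min/kg, within 50 mL/min/kg to 250 mL/min/kg, in this assay. The step this implies, a 1.1-fold higher number from compound 1 to compound 4 (0.05 log units; within the scatter), is expected to stay within the scatter.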

Compound 4, clearance: < 33.4 mL/min/kg
Compound 4 was reported as a limit (the forecaster's own chance of this, stated with the estimate: 5%); middle value at least 3.2-fold (0.51 log units) away from the limit.
By their numbers in this assay, from the lowest: compounds 1, 3 and 2 (each within the scatter of the next). At a limit, below all of these: compound 4.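

Replacing tert-butoxycarbonyl with (1,3-oxazol-2-yl)methyl on the amide-type nitrogen gives an at least 2.9-fold lower number from compound 1 to compound 4 (0.46 log units; beyond the scatter) in this assay, the first step shown in the series that lies beyond the scatter. The group on this nitrogen of the five-membered non-aromatic ring with 2 nitrogen can therefore shift the clearance, which the earlier fluoro step could not show. Compound 4 stands only as a limit, so the full size of the step remains unfixed: the limit of < 33.4 mL/min/kg in this assay, at which 1 of the 4 values shown sits.

The compounds shown do not separate the departure of tert-butoxycarbonyl from the arrival of (1,3-oxazol-2-yl)methyl, since none carries a plain hydrogen or a methyl on this nitrogen. On these data alone, it also remains open whether a thiazolylmethyl, a longer chain ending in the same oxazole, or an amine at this position would give a similar result.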